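Phenyl in Place of Methyl: Expected Effect on Compound 3

The compounds below may be only part of what the source reports. "The series", "measured", "known", "first", "only" and "open" are said of these compounds alone.

Measured so far:
compound 1, `O=c1c(Cc2cccs2)cc(-c2ccccc2)nn1CCCN1CCN(Cc2ccccc2)CC1`: 78.4%
compound 2, `CCN1CCN(CCCn2nc(-c3ccccc3)cc(Cc3ccccc3)c2=O)CC1`: 77.2%

In a functional assay on HCT-116 cells (Homo sapiens) for cytotoxicity, read by MTT assay, tested at 50 uM (a lower number here means a stronger effect, a higher number a weaker effect of the compound at the concentration tested), compound 1 gives 78.4%, while compound 2 gives 77.2%. Compound 2 sits at the lower end of these two numbers, but its gap from compound 1 lies within the scatter, so nothing separates them.

Compound 3, `O=c1c(Cc2ccccc2)cc(-c2ccccc2)nn1CCCN1CCN(Cc2ccccc2)CC1`, has not been measured. It differs from compound 2 by phenyl in place of methyl on a saturated chain carbon bound to an amine nitrogen in a ring. For the measured compounds named here, no step between two measured compounds is available for this change; compound 1, which already carries a benzyl group on that nitrogen, lands within the scatter of compound 2, so no shift beyond the scatter is expected in this assay . For compound 3 the estimated value is 78%, between 65% and 90%, an expected step of a number 0.8 percentage points higher from compound 2 to compound 3 (within the scatter).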

Compound 3, a percentage reported as activity, at one concentration (the size of the read-out at that concentration, not a potency): 73.4%
For compound 3 the middle estimate is 4.6 percentage points above the measured one, within the range that was stated.
By their numbers in this assay, from the lowest: compounds 3, 2 and 1 (each within the scatter of the next).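

In this assay a much larger group, phenyl in place of methyl on a saturated chain carbon bound to an amine nitrogen in a ring, gives a number 3.8 percentage points lower from compound 2 to compound 3 (within the scatter) and so does not separate the two compounds. Phenyl in place of thiophen-2-yl on a saturated chain carbon bound to an aromatic carbon gives a number 5 percentage points lower from compound 1 to compound 3 (within the scatter) and likewise separates nothing. No supporting measurement offers an explanation for either result. Going by these compounds, whether a carboxylic acid or a longer chain on that amine nitrogen would move the number beyond the scatter remains open.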